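Cyclic sulfonate series, cytotoxicity notes on the ether side chain

The source may hold more compounds than are shown below. What is called first, only, known or untested is meant among the compounds shown, and "the series" means these compounds.

Measured so far:
compound 1 `CCC1(Cc2ccccc2)OS(=O)(=O)C=C1OCCCCc1ccccc1` — >= 20000 nM
compound 2 `CCC1(Cc2ccccc2)OS(=O)(=O)C=C1OCc1ccc(F)cc1` — >= 50000 nM

In an ADME assay on HEL cells (Homo sapiens) for cytotoxicity, with a stated time of 3 days (on this read-out lower numbers stand for higher toxicity in this test and higher numbers for lower toxicity in this test), compound 1 gives >= 20000 nM, which is a limit of the assay and not a number. Compound 2 gives in this assay >= 50000 nM, again a limit and not a number. The step that the two limits leave unreadable from compound 1 to compound 2 therefore cannot be read in size or direction; the two values sit at the limit of >= 20000 nM in this assay, at which 1 of the 2 values shown sits, and (the limit of >= 50000 nM in this assay, at which 1 of the 2 values shown sits), and nothing more can be drawn from them than that neither compound reached a measurable cytotoxic concentration within its range.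

Compound 3 `CCC1(Cc2ccccc2)OS(=O)(=O)C=C1OCc1ccc(C(C)(C)C)cc1` follows from compound 2 by tert-butyl in place of fluoro on an aromatic carbon. Among the compounds with values here, no measured step bears on a change at this position; the only step on hand, from compound 1 to compound 2, is itself unreadable. For compound 3 the expectation is simply the same region as compound 2, with a step of an at least 1.2-fold lower number from compound 2 to compound 3 (0.09 log units; that floor lies within the scatter) expected to stay within the scatter. Compound 3 is therefore estimated at 40000 nM, with a range from 12000 nM to 100000 nM, and a limit rather than a number is the likelier outcome.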

Compound 3, minimum cytotoxic concentration: >= 400000 nM
Compound 3: only a limit was reported; the forecaster's own chance of this, stated with the estimate: 60%; middle value at least 10-fold (1.00 log units) from the limit.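

In this assay compound 3 gives >= 400000 nM, a limit and not a number. Compound 2 also stands at a limit, so the change from compound 2 to compound 3 cannot be read in size or direction. The compounds shown leave open what numerical cytotoxic concentration, if any, belongs to any member of this series.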